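The compounds below may be only part of what the source reports. "The series", "measured", "known", "first", "only" and "open" are said of these compounds alone.

In a functional assay on MGC-803 cells (Homo sapiens) for inhibition, read by MTT assay, with a stated time of 72 h (on this read-out lower numbers stand for stronger inhibition and higher numbers for weaker inhibition), three compounds with a shared core have been measured: compound 1 `COc1ccc(NC(=O)C2CCN(C/C=C/c3ccccc3)CC2)cc1` gives 58200 nM while compound 2 `O=C(Nc1cccc(Cl)c1)C1CCN(C/C=C/c2ccccc2)CC1` gives 11300 nM and compound 3 `O=C(Nc1cccc(Br)c1)C1CCN(C/C=C/c2ccccc2)CC1` gives 9110 nM on the same read-out. Compound 3 therefore sits at the stronger end of this short series, together with compound 2: a 1.2-fold lower number from compound 2 to compound 3 (0.09 log units; within the scatter) is no real difference.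

Compound 4 `O=C(NCc1ccccc1)C1CCN(C/C=C/c2ccccc2)CC1` has not yet been measured. It carries benzyl in place of 3-bromophenyl on an amide-type nitrogen. Among the measured compounds shown here, the steps that bear on this are swaps on that same nitrogen: a 5.2-fold lower number from compound 1 to compound 2 (0.71 log units; beyond the scatter) and a 6.4-fold lower number from compound 1 to compound 3 (0.81 log units; beyond the scatter) are both modest. For the measured compounds named here, no measured compound has benzyl there, so the size of the step remains uncertain. Going by the values given here, compound 4 has no halogen, and the only measured compound without one is compound 1 (58200 nM). A modest move towards weaker inhibition is therefore expected, and the estimated change is a 2.7-fold higher number from compound 3 to compound 4 (0.44 log units; beyond the scatter) in all. For compound 4 the expected value is 25000 nM within an estimated range of 8000 nM to 80000 nM in this assay.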

Compound 4, half-maximal inhibitory concentration: > 100000 nM
Compound 4 gave a limit, no number (the forecaster's own chance of this, stated with the estimate: 10%); middle value at least 4.0-fold (0.60 log units) away from the limit.
By their numbers in this assay, from the lowest: compounds 3 and 2 (each within the scatter of the next); then compound 1. At a limit, above all of these: compound 4.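

The earlier compounds shown here changed only the substituents on a phenyl group sitting on the amide-type nitrogen. Benzyl and 3-bromophenyl have the same count of heavy atoms and each holds one six-membered aromatic ring, yet in this assay this swap gives an at least 10-fold higher number from compound 3 to compound 4 (1.04 log units; beyond the scatter), so this position responds strongly to more than the phenyl substituents, and the swap from the chloro analogue agrees, with an at least 8.8-fold higher number from compound 2 to compound 4 (0.94 log units; beyond the scatter), while the comparison with the methoxy analogue, an at least 1.7-fold higher number from compound 1 to compound 4 (0.23 log units; that floor lies within the scatter), fixes no clear gap. The reading for compound 4 is a limit of the assay, not a number: the limit of > 100000 nM in this assay, at which 1 of the 4 values shown sits.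

The compounds shown do not separate the loss of the halogen from the change to benzyl; a plain phenyl or a 3-bromobenzyl on that nitrogen would pull the two apart. They also leave open how a longer chain such as 2-phenylethyl would behave there.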